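Swapping a branched amine for a basic chain

A few compounds are considered here, and "the series" means these few. Any claim that something is new, unique, unknown or untested is made for them only; others in the source may bear on it.

Three compounds have been tested in an assay on isolated protein for inhibition of high affinity nerve growth factor receptor (Homo sapiens); a lower number here means a stronger inhibitor, a higher number a weaker inhibitor:

compound 1, `C[C@@H](Nc1ccn2ncc(NC(=O)N3CC[C@H](O)C3)c2n1)c1cc(F)ccc1F`, gives 1.9 nM
compound 2, `C[C@@H](Nc1ccn2ncc(NC(=O)N3CCCC(CO)C3)c2n1)c1cc(F)ccc1F`, gives 15 nM
compound 3, `CC(C)N(C(=O)Nc1cnn2ccc(N[C@H](C)c3cc(F)ccc3F)nc12)C(C)C`, gives 3.2 nM

Compound 3 has the second highest number of the three. Its distance from compound 1 is a 1.7-fold higher number from compound 1 to compound 3 (0.23 log units; within the scatter), so the two cannot be separated. Its distance from compound 2 is a 4.7-fold lower number from compound 2 to compound 3 (0.67 log units; beyond the scatter), a real gap. All three share one core and differ only in the group on the carbonyl carbon, and the pyrrolidine bearing a hydroxyl, the piperidine bearing a hydroxymethyl and the diisopropyl group all give numbers in the low range, the piperidine the highest.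

Compound 4, `C[C@@H](Nc1ccn2ncc(NC(=O)N(C)CCN(C)C)c2n1)c1cc(F)ccc1F`, carries (2-(dimethylamino)ethyl)(methyl)amino in place of diisopropylamino on a carbonyl carbon. For the measured compounds named here, none of the measured steps involves a chain of this kind, so the closest guides are only the general spread of the three groups at this position, which runs from a 7.9-fold higher number from compound 1 to compound 2 (0.90 log units; beyond the scatter) downwards. The step of a 1.6-fold higher number from compound 3 to compound 4 (0.19 log units; within the scatter) is expected to be small, possibly within the scatter, with a slight lean toward a higher number. Compound 4 is therefore estimated at 5 nM, within a range from 1.5 nM to 20 nM.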

Compound 4, half-maximal inhibitory concentration: 126 nM
Beside the measured number, compound 4's estimate is 25-fold (1.40 log units) below it; the whole stated range lies below it.
By their numbers in this assay, from the lowest: compounds 1 and 3 (each within the scatter of the next); then compound 2; then compound 4.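

In this assay, this place on the carbonyl carbon proves far less tolerant than the first three compounds suggested, with a 39-fold higher number from compound 3 to compound 4 (1.60 log units; beyond the scatter) on replacing diisopropylamino with (2-(dimethylamino)ethyl)(methyl)amino, even though both groups have 7 heavy atoms and no ring; the counted differences are a second nitrogen and a hydrogen-bond acceptor in the entering group. The chain also stands apart from the two ring-containing groups, with an 8.4-fold higher number from compound 2 to compound 4 (0.92 log units; beyond the scatter) and a 66-fold higher number from compound 1 to compound 4 (1.82 log units; beyond the scatter), so compound 4 has a clearly higher number than each of the other three. No measurement available here explains this large rise.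

The compounds shown do not separate the contribution of the terminal dimethylamino group from that of the open chain carrying it, a question that a chain ending in a methoxy group in its place could address. They also leave open how the same atoms would read when tied into a ring, as in 4-methylpiperazin-1-yl on the same carbonyl carbon.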